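What compound 4 may lose against compound 3

A few compounds are considered here, and "the series" means these few. Any claim that something is new, unique, unknown or untested is made for them only; others in the source may bear on it.

Values measured in a functional assay on MGC-803 cells (Homo sapiens) for antiproliferative activity, read by MTT assay, with a stated time of 72 h (on this read-out lower numbers stand for stronger inhibition and higher numbers for weaker inhibition), are these
compound 1 `CCCSc1nc(N/N=C/c2cccnc2)c2nnn(Cc3ccccc3)c2n1` gives 38100 nM
compound 2 `CCCSc1nc(N/N=C/c2ccc(Cl)cc2)c2nnn(Cc3ccccc3)c2n1` gives > 64000 nM as a limit
compound 3 `CCCSc1nc(N/N=C(\C)c2ccccc2O)c2nnn(Cc3ccccc3)c2n1` gives 2310 nM as a number

For compound 2 the entry of > 64000 nM is a limit of the assay and not a number. Of the two actual numbers, compound 3 holds the lower, and compound 1 is its nearest neighbour. Compound 4 `CCCSc1nc(N/N=C/c2ccccc2)c2nnn(Cc3ccccc3)c2n1` has not yet been measured. Set against compound 3 it shows a group of 8 heavy atoms (7 carbon, 1 nitrogen; one six-membered aromatic ring of carbon only) in place of a group of 10 heavy atoms (8 carbon, 1 nitrogen, 1 oxygen; one six-membered aromatic ring of carbon only), on a nitrogen on an aromatic ring and the group that enters has 0 hydrogen-bond donors, where the group that leaves has 1 hydrogen-bond donor. Two large measured steps bear on this change, a 16-fold lower number from compound 1 to compound 3 (1.22 log units; beyond the scatter) and an at least 27-fold lower number from compound 2 to compound 3 (1.44 log units; beyond the scatter) and both are beyond the scatter. Each ends at compound 3, which alone carries the group that compound 4 gives up, so a large rise in the number is expected, meaning weaker inhibition. The expected change is a 10-fold higher number from compound 3 to compound 4 (1.02 log units; beyond the scatter) in this assay by this estimate. For compound 4 the estimated value is 24000 nM with an expected range from 7000 nM to 64000 nM as the likely span.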

Compound 4, half-maximal inhibitory concentration: > 64000 nM
Compound 4: only a limit was reported; the forecaster's own chance of this, stated with the estimate: 20%; middle value at least 2.6-fold (0.42 log units) from the limit.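

In this assay, the change from the group of compound 3 to the plain phenyl group gives an at least 27-fold higher number from compound 3 to compound 4 (1.44 log units; beyond the scatter), so the gain seen in compound 3 does not survive on the phenyl ring alone, and the chloro of compound 2 is not needed for the loss. For the other neighbour the result is an at least 1.6-fold higher number from compound 1 to compound 4 (0.22 log units; that floor lies within the scatter), a floor that sets no order between the pyridin-3-yl and phenyl groups, and the steps that join compound 4 to compound 2 cannot be read. The value of compound 4 is a limit and not a number: the limit of > 64000 nM in this assay, at which 2 of the 4 values shown sit.

Compound 3 differs from compound 4 in both a methyl group on the carbon with a double bond to nitrogen and a hydroxyl on the phenyl ring, and the compounds shown do not separate the two. As far as these compounds go, how a methoxy group or an amine in place of that hydroxyl would read stays open.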